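The compounds below may be only part of what the source reports. "The series", "measured", "known", "first", "only" and "open" are said of these compounds alone.

Measured so far: compound 1 `Cc1nc2cnc(C(=O)NC3CN(c4cc(Cl)ncc4Cl)C3)cn2c1C` at 0.034; compound 2 `Cc1c2cc(C(=O)NC3CN(c4cc(Cl)ncc4Cl)C3)ncc2nn1C` at 0.03; compound 3 `Cc1c2cc(C(=O)NC3CN(c4cc(Cl)ncc4Cl)C3)ccc2nn1C` at 0.032.

All three values come from an ADME assay on brain (Rattus norvegicus) for protein binding; a higher number here means a larger unbound share of the compound, a lower number a smaller unbound share. Compound 1 gives 0.034, and the numbers of compound 2 and compound 3 lie within the scatter of it, so the three compounds cannot be told apart on this assay. Within the data shown here, no step between measured compounds that differ in one place is available.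

Compound 4 `COc1cc(N2CC(NC(=O)c3cn4c(C)c(C)nc4cn3)C2)c(Cl)cn1` has not yet been measured. It differs from compound 1 by methoxy in place of chloro on an aromatic carbon. Among the measured compounds shown here, with no measured step of this kind to lean on, the change from compound 1 to compound 4 is expected to be small, at most a modest rise in this assay, and the step of a 1.5-fold higher number from compound 1 to compound 4 (0.17 log units; within the scatter) is the estimate. Compound 4 is therefore expected to give about 0.05, with a range from 0.025 to 0.1.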

Compound 4, unbound fraction: 0.021
Estimate against measurement, compound 4: 2.4-fold (0.38 log units) above, outside the stated range (below it).
By their numbers in this assay, from the lowest: compounds 4, 2, 3 and 1 (each within the scatter of the next).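

In this assay, methoxy in place of chloro on the aromatic carbon next to the ring nitrogen gives a 1.6-fold lower number from compound 1 to compound 4 (0.21 log units; within the scatter). Among these compounds, this is the first reading at this place, since the earlier compounds share this ring unchanged, and it does not separate the two groups. Nothing measured here offers an explanation for the step. Still open, going by these compounds, is whether an amine or a nitrile at this place would also stay within the scatter of compound 1. Also open, on these data alone, is whether methoxy would read the same on the cores of compound 2 and compound 3.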